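Changing the amino side chain of compound 1

A few compounds are considered here, and "the series" means these few. Any claim that something is new, unique, unknown or untested is made for them only; others in the source may bear on it.

In an ADME assay on Vero cells (Chlorocebus sabaeus) for cytotoxicity, with a stated time of 5 days (on this read-out higher numbers stand for weaker inhibition and lower numbers for stronger inhibition), compound 1 `CC(C)(CO)Nc1nc(N)nc2c1ncn2[C@H]1C[C@H](N=[N+]=[N-])[C@@H](CO)O1` gives > 100000 nM, which is a limit and not a number. Compound 2 `[N-]=[N+]=N[C@H]1C[C@H](n2cnc3c(NC4CC4)nc(Cl)nc32)O[C@@H]1CO` gives > 100000 nM, also a limit. Compound 3 `[N-]=[N+]=N[C@H]1C[C@H](n2cnc3c(Cl)nc(F)nc32)O[C@@H]1CO` gives a true number, 21800 nM. Compound 1 thus stands at the limit of > 100000 nM in this assay, at which 2 of the 3 values shown sit. Compound 4 `C=CCN(C)c1nc(N)nc2c1ncn2[C@H]1C[C@H](N=[N+]=[N-])[C@@H](CO)O1` departs from compound 1 in one place: allyl(methyl)amino in place of (1-(hydroxymethyl)-1-methylethyl)amino on an aromatic carbon. Going by the values given here, no measured pair shows this change, so only a rough expectation is possible. Compound 3 at 21800 nM shows that a number can be read on related structures, which leaves room for a modest move toward stronger inhibition. The expected step is an at least 1.2-fold lower number from compound 1 to compound 4 (0.09 log units; that floor lies within the scatter). For compound 4 the estimate is 80000 nM, with an expected range from 30000 nM to 150000 nM.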

Compound 4, half-maximal inhibitory concentration: 32000 nM
Compound 4: middle estimate off by 2.5-fold (0.40 log units), on the high side; the range from low to high includes it.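

In this assay, the aromatic carbon carrying the amino side chain proves able to move the read-out: allyl(methyl)amino in place of (1-(hydroxymethyl)-1-methylethyl)amino gives an at least 3.1-fold lower number from compound 1 to compound 4 (0.49 log units; beyond the scatter). The leaving group has 2 hydrogen-bond donors and the entering group has 0, but this one step cannot separate that difference from the others between the two groups. Compound 1 stands only at a limit, so the full size of the step stays unknown: the limit of > 100000 nM in this assay, at which 2 of the 4 values shown sit.

Whether the double bond of the allyl group or the methyl on the nitrogen accounts for the step remains open. So does the outcome with a dimethylamino group or a longer alkyl chain at this position.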